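The source may hold more compounds than are shown below. What is called first, only, known or untested is meant among the compounds shown, and "the series" means these compounds.

In a functional assay on MCF7 cells (Homo sapiens) for antiproliferative activity, read by MTT assay, with a stated time of 72 h (on this read-out higher numbers stand for weaker inhibition and lower numbers for stronger inhibition), compound 2 (`C/C=C1/[C@H](O[C@@H]2O[C@H](CO)[C@@H](O)[C@H](O)[C@H]2O)OC=C(C(=O)OC)[C@H]1CC(=O)OCCC(C)C`) gives 21300 nM as the higher of two numbers, with compound 1 (`C/C=C1/[C@H](O[C@@H]2O[C@H](CO)[C@@H](O)[C@H](O)[C@H]2O)OC=C(C(=O)OC)[C@H]1CC(=O)OCCC1CCCCC1`) at 5000 nM as the lower. Compound 3 (`C/C=C1/[C@H](O[C@@H]2O[C@H](CO)[C@@H](O)[C@H](O)[C@H]2O)OC=C(C(=O)OC)[C@H]1CC(=O)OCCc1ccccc1`) carries phenyl in place of isopropyl on a saturated chain carbon, two bonds along the chain from an oxygen next to a carbonyl group. Among the compounds with values here, the one measured step at that place (a 4.3-fold higher number from compound 1 to compound 2 (0.63 log units; beyond the scatter)) is modest and beyond the scatter, and it replaces cyclohexyl with isopropyl. Phenyl returns a six-membered ring, so a modest step to a lower number is expected, though no phenyl compound has been measured yet. The estimated step (a 2.4-fold lower number from compound 2 to compound 3 (0.37 log units; beyond the scatter)) would stay modest. Compound 3 is estimated at 9000 nM (range 3000 nM to 25000 nM).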

Compound 3, half-maximal inhibitory concentration: 19300 nM
The estimate for compound 3 lay 2.1-fold (0.33 log units) below the measured number, and the stated range covers the measured number.
By their numbers in this assay, from the lowest: compound 1; then compounds 3 and 2 (each within the scatter of the next).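

In this assay, a six-membered ring at this place does not by itself match cyclohexyl: phenyl and isopropyl cannot be told apart, with a 1.1-fold lower number from compound 2 to compound 3 (0.04 log units; within the scatter) and no change beyond the scatter. Cyclohexyl stands apart from phenyl, with a 3.9-fold higher number from compound 1 to compound 3 (0.59 log units; beyond the scatter) as the step between two rings of the same size. Among these three compounds, only the cyclohexyl of compound 1 gives a distinctly lower number. As far as these compounds go, how a cyclopentyl ring, a pyridine ring or a terminal amine would read at this place remains open. The available information offers no explanation for what sets cyclohexyl apart.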